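Trimming the Side Chain in a Solubility Series

The compounds below may be only part of what the source reports. "The series", "measured", "known", "first", "only" and "open" are said of these compounds alone.

Compound 2 `CCC(C(=O)O)c1nn(Cc2cn3cc(OCC4CC4)c(Cl)cc3n2)c2ccccc2c1=O` stands alongside compound 3 `CC(C(=O)O)c1nn(Cc2cn3cc(OCC4CC4)c(C(F)(F)F)cc3n2)c2ccccc2c1=O` and compound 1 `O=C(O)Cn1nc(Cc2nc3cc(Cl)c(OCC(F)F)cc3[nH]2)c2ccccc2c1=O` as one of three acids built on a shared core. For the measured compounds named here, in a physicochemical assay for solubility, measured as thermodynamic solubility, at pH 7.4 (on this read-out higher numbers stand for higher solubility and lower numbers for lower solubility), compound 2 gives 359 ug/mL, the higher of the two numbers known, while compound 3 gives 221 ug/mL; the two sit within the usual scatter of one another. Compound 1 reaches only a limit of this assay at > 1000 ug/mL, consistent with the limit of > 1000 ug/mL in this assay, at which 1 of the 3 values shown sits. Compound 4 `O=C(O)Cc1nn(Cc2cn3cc(OCC4CC4)c(Cl)cc3n2)c2ccccc2c1=O` differs from compound 2 by hydrogen in place of ethyl on a saturated chain carbon bound to an aromatic carbon and a carbonyl carbon. Going by the values given here, no measured step covers this change; an increase beyond the scatter is nonetheless expected for the step of a 2.1-fold higher number from compound 2 to compound 4 (0.32 log units; beyond the scatter). Compound 4 is therefore estimated at 750 ug/mL, within a range from 320 ug/mL to 1500 ug/mL.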

Compound 4, solubility: 919 ug/mL
Estimate against measurement, compound 4: 1.2-fold (0.09 log units) below; measured number inside the range.
By their numbers in this assay, from the lowest: compounds 3 and 2 (each within the scatter of the next); then compound 4. At a limit, above all of these: compound 1.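

In this assay, replacing ethyl with hydrogen on the saturated chain carbon bound to an aromatic carbon and a carbonyl carbon gives a 2.6-fold higher number from compound 2 to compound 4 (0.41 log units; beyond the scatter). For the compounds shown here, the earlier compounds offered no pair differing in one place, so this is the only direct reading of a change at this position, and it lies beyond the scatter. Compound 1 alone remains at a limit: the limit of > 1000 ug/mL in this assay, at which 1 of the 4 values shown sits.

The compounds shown leave open how a longer chain or an amine on this carbon would read. They also leave open whether the step holds with trifluoromethyl in place of chlorine on the shared core.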